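Piperidine Replaces Diethylamino on the Chain of Compound 3

The source may hold more compounds than are shown below. What is called first, only, known or untested is meant among the compounds shown, and "the series" means these compounds.

Three compounds have been measured in a functional assay on HepG2 cells (Homo sapiens) for antiproliferative activity, read by MTT assay, with a stated time of 48 h; a higher number here means a weaker inhibitor, a lower number a stronger inhibitor:

Compound 1 `COc1cc2oc(-c3ccccc3)cc(=O)c2c(O)c1OCCCN1CCN(C)CC1`: 15100 nM
Compound 2 `O=c1cc(-c2ccccc2)oc2cc(OCc3ccccc3)c(OCCCCN3CCCCC3)c(O)c12`: 2400 nM
Compound 3 `CCN(CC)CCCCOc1c(OC)cc2oc(-c3ccccc3)cc(=O)c2c1O`: 7100 nM

Compound 3 sits second highest of the three numbers. Among the measured compounds shown here, the one single-point step runs a 2.1-fold lower number from compound 1 to compound 3 (0.33 log units; beyond the scatter). Compound 2, which differs from compound 3 in more than one place, gives a lower number.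

Compound 4 `COc1cc2oc(-c3ccccc3)cc(=O)c2c(O)c1OCCCCN1CCCCC1` is the next to be measured. It differs from compound 3 by piperidin-1-yl in place of diethylamino on a saturated chain carbon, four bonds along the chain from an oxygen on an aromatic ring. For the measured compounds named here, the only step that bears on changing the amine tail is modest, and compound 2, which also carries piperidin-1-yl on a chain, gives 2400 nM. A modest lower number is therefore expected, a 1.6-fold lower number from compound 3 to compound 4 (0.20 log units; within the scatter). Compound 4 is estimated at 4500 nM, in the range 1800 nM to 11000 nM.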

Compound 4, half-maximal inhibitory concentration: 21000 nM
Beside the measured number, compound 4's estimate is 4.7-fold (0.67 log units) below it; the measured number lies above the stated range.
By their numbers in this assay, from the lowest: compound 2; then compound 3; then compounds 1 and 4 (each within the scatter of the next).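

In this assay closing diethylamino into the piperidin-1-yl ring on this chain weakens the compound (a 3.0-fold higher number from compound 3 to compound 4 (0.47 log units; beyond the scatter)). Piperidin-1-yl alone therefore does not bring the low number of compound 2; the largest step so far is hydrogen in place of phenyl on the carbon bound to the aromatic oxygen (an 8.8-fold higher number from compound 2 to compound 4 (0.94 log units; beyond the scatter)), while the tails of the remaining pair stay within the scatter (a 1.4-fold higher number from compound 1 to compound 4 (0.14 log units; within the scatter)). No measurement here explains either step.

On these data alone, whether a morpholin-4-yl tail on the same chain would behave like piperidin-1-yl or like diethylamino remains open. So does whether the phenyl gain holds with a diethylamino tail.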